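An Ethyl Added Where Clearance Already Sits at a Limit

This account rests on a few compounds, and the source may have more. Where it says the series, first, only, none or still open, it means among the compounds named here.

Three compounds with a shared core were run in an ADME assay on microsomes from liver (Homo sapiens) for metabolic stability; on this read-out higher numbers stand for fast clearance and lower numbers for slow clearance. Compound 1 `Cc1ccc(NC(=O)c2cc(Oc3ccc(S(C)(=O)=O)cc3)cc(OC(C)C)c2)nc1` gives 17 mL/min/kg in this assay. Compound 2 `CC(C)Oc1cc(Oc2ccc(S(C)(=O)=O)cc2)cc(-c2cccc(=O)[nH]2)c1` gives only a limit in this assay, < 8 mL/min/kg. Compound 3 `CC(C)Oc1cc(Oc2ccc(S(C)(=O)=O)cc2)cc(-c2nccc(=O)[nH]2)c1` also gives only a limit in this assay, < 9.8 mL/min/kg. Between the measured compounds, an at least 2.1-fold lower number from compound 1 to compound 2 (0.32 log units; beyond the scatter), and an at least 1.7-fold lower number from compound 1 to compound 3 (0.23 log units; that floor lies within the scatter), while the difference between compound 2 and compound 3 is a step that the two limits leave unreadable from compound 2 to compound 3. Compound 3 therefore stands at a limit, (the limit of < 9.8 mL/min/kg in this assay, at which 1 of the 3 values shown sits), and compound 2 stands at the other limit shown, (the limit of < 8 mL/min/kg in this assay, at which 1 of the 3 values shown sits).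

Compound 4 `CCc1cnc(-c2cc(Oc3ccc(S(C)(=O)=O)cc3)cc(OC(C)C)c2)[nH]c1=O` differs from compound 3 by ethyl in place of hydrogen on an aromatic carbon. Going by the values given here, none of the measured steps concerns an ethyl in place of hydrogen; all of them exchange one six-membered aromatic ring for another on the same aromatic carbon. No step beyond the scatter is therefore expected, and compound 4 is expected to show an at least 1.0-fold higher number from compound 3 to compound 4 (0.00 log units; that floor lies within the scatter) in this assay. Compound 4 is estimated at 10 mL/min/kg, with a range from 5 mL/min/kg to 20 mL/min/kg.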

Compound 4, clearance: < 8 mL/min/kg
Compound 4 gave a limit, no number (the forecaster's own chance of this, stated with the estimate: 40%); middle value at least 1.2-fold (0.09 log units) from the limit.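

With ethyl in place of hydrogen on this aromatic carbon, para to a large group, compound 4 still gives only a limit in this assay, so the change brings no readable clearance value at this position: the limit of < 8 mL/min/kg in this assay, at which 2 of the 4 values shown sit. The steps from compound 2 and from compound 3 to compound 4 cannot be read, as each joins two limits. The ethyl-bearing compound still shows an at least 2.1-fold lower number from compound 1 to compound 4 (0.32 log units; beyond the scatter), a floor that lies beyond the scatter, which the floor of the step from compound 1 to compound 3 did not.

How far the ethyl moves clearance, in either direction, stays hidden behind these limits. As far as these compounds go, whether a longer chain such as butyl, or an amine or a carboxylic acid, on the same carbon would give a readable value in this assay also remains open.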